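Shifting the chlorine on a pyridine-based topoisomerase inhibitor

The compounds below may be only part of what the source reports. "The series", "measured", "known", "first", "only" and "open" are said of these compounds alone.

Measured so far:
Compound 1, `Oc1ccc(-c2cc(-c3cccs3)nc(-c3ccccc3Cl)c2)cc1`, 2.2%
Compound 2, `Oc1ccc(-c2cc(-c3cccc(Cl)c3)nc(-c3ccco3)c2)cc1`, 25.5%

Of the compounds shown here, two have been tested in an assay on isolated protein for inhibition of DNA topoisomerase 1 (Homo sapiens), with a stated time of 30 min, tested at 100 uM; on this read-out lower numbers stand for a weaker effect and higher numbers for a stronger effect at the one concentration tested. Compound 1 gives 2.2% in this assay. Compound 2 gives 25.5% in this assay, the higher of the two numbers, and its gap to compound 1 lies beyond the scatter. Among the compounds with values here, the two differ in more than one place, so their values show only that compound 2 inhibits more strongly than compound 1 under these conditions.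

Compound 3, `Oc1ccc(-c2cc(-c3ccco3)nc(-c3ccccc3Cl)c2)cc1`, has not yet been measured. It keeps every atom of compound 2 but joins them differently: 2-chlorophenyl in place of 3-chlorophenyl on an aromatic carbon. Within the data shown here, the chlorine now sits on the aryl ring next to the ring nitrogen as it does in compound 1, although compound 3 carries a furan-2-yl group where compound 1 carries a thiophene ring, so no single step leads from the measured compounds to compound 3. Among the measured compounds shown here, because compound 1, the only measured compound with a 2-chlorophenyl group, gives 2.2%, a step downward from compound 2 is expected, likely beyond the scatter. Compound 3 is estimated at 10% in this assay, within 0% to 28%, which corresponds to an expected step of a number 15.5 percentage points lower from compound 2 to compound 3 (beyond the scatter).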

Compound 3, a percentage reported as inhibition, at one concentration (the size of the read-out at that concentration, not a potency): 3.9%
Compound 3: the middle estimate sits 6.1 percentage points above what was measured; the range from low to high includes it.
By their numbers in this assay, from the lowest: compounds 1 and 3 (each within the scatter of the next); then compound 2.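

Within the data shown here, with the furan-2-yl group held fixed, this assay gives the first comparison that isolates the chlorine: 2-chlorophenyl in place of 3-chlorophenyl brings a number 21.6 percentage points lower from compound 2 to compound 3 (beyond the scatter), even though the two compounds have the same atoms, so where the chlorine sits on this aryl ring matters in this read-out. With the 2-chlorophenyl group held fixed, furan-2-yl in place of thiophen-2-yl brings a number 1.7 percentage points higher from compound 1 to compound 3 (within the scatter), so this exchange does not separate the two compounds on that background. Nothing available explains why the chlorine's position changes the read-out.

As far as these compounds go, it remains open whether the step seen with the furan-2-yl group would recur with thiophen-2-yl, that is, whether a 3-chlorophenyl group would also give a higher number beside that ring than a 2-chlorophenyl group does. Also open, from the compounds shown here alone, is how an amine or a methoxy group in the chlorine's place would read in this assay, and, as each number comes from one concentration and is not a potency, how these compounds would compare across a range of concentrations.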